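A few compounds are considered here, and "the series" means these few. Any claim that something is new, unique, unknown or untested is made for them only; others in the source may bear on it.

Measured so far:
Compound 1, `O=C(Nc1cccc(CNc2ncnc3ccccc23)c1)Nc1ccccc1F`, 17500 nM in a functional assay on HepG2 cells (Homo sapiens) for antiproliferative activity, read by MTT assay; on this read-out lower numbers stand for stronger inhibition and higher numbers for weaker inhibition.
Compound 2, `O=C(Nc1cccc(CNc2ncnc3ccccc23)c1)Nc1ccccc1Cl`: in this assay compound 2 gives only a limit, > 50000 nM.
Compound 3, `COc1cc2ncnc(NCc3cccc(NC(=O)Nc4ccccc4)c3)c2cc1OC`, 19700 nM.

Compound 3 and compound 1 give numbers that lie within the usual scatter of each other, so no order between them is claimed. Compound 2 gives a limit and no number, which is the case for one of the three values shown (the limit of > 50000 nM in this assay, at which 1 of the 3 values shown sits).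

The step considered here leads from compound 3 to compound 4, `COc1cc2ncnc(NCc3cccc(NC(=O)Nc4cccc(C)c4)c3)c2cc1OC`. The change is methyl in place of hydrogen on an aromatic carbon: the phenylcarbamoyl end becomes a (3-methylphenyl)carbamoyl end. Within the data shown here, none of the measured steps makes this same change. Among the measured compounds shown here, the only step measured on the phenylurea ring is an at least 2.8-fold higher number from compound 1 to compound 2 (0.45 log units; beyond the scatter), and that change is a different one, chloro for fluoro, so it gives little guidance on a methyl for hydrogen. For the measured compounds named here, with no direct precedent, the step is expected to stay close to the scatter.

Compound 4 is therefore estimated at about 20000 nM, with a range from 8000 nM to 50000 nM. For compound 4 this expectation amounts to a step of a 1.0-fold higher number from compound 3 to compound 4 (0.01 log units; within the scatter).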

Compound 4, half-maximal inhibitory concentration: 21500 nM
Compound 4: the middle estimate sits 1.1-fold (0.03 log units) below what was measured; the measured number falls inside the stated range.
By their numbers in this assay, from the lowest: compounds 1, 3 and 4 (each within the scatter of the next). At a limit, above all of these: compound 2.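

On the core of compound 3, methyl in place of hydrogen on the aromatic carbon meta to a large group, which turns phenyl into 3-methylphenyl, makes no difference that can be read in this assay: the result is a 1.1-fold higher number from compound 3 to compound 4 (0.04 log units; within the scatter). Among these compounds, this is the first measured step at this position and the first for this change, as the only earlier step was chloro in place of fluoro on the core of compound 1, which lay beyond the scatter and so showed that a change on this ring can matter. Here, by contrast, the added carbon leaves compound 4 within the scatter of compound 3, although nothing measured here gives a reason for this outcome.

The compounds shown leave open whether a longer chain such as ethyl, an amine or a carboxylic acid at this same place would also stay within the scatter of compound 3. They also leave open whether methyl in place of hydrogen would give a similar result on the core of compound 1, or on another carbon of the same ring.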